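This account rests on a few compounds, and the source may have more. Where it says the series, first, only, none or still open, it means among the compounds named here.

Measured compounds in a functional assay on MCF7 cells (Homo sapiens) for inhibition, read by sulforhodamine B assay, with a stated time of 48 h; on this read-out lower numbers stand for higher toxicity in this test and higher numbers for lower toxicity in this test:

- Compound 1, `COc1cc(CNc2nc3cc(N)cc(N)c3nc2-c2ccccc2)cc(OC)c1OC`: compound 1 gives < 50200 nM, which is a limit of the assay and not a number.
- Compound 2, `Nc1cc(N)c2nc(-c3ccccc3)c(Sc3ccc(Cl)c(Cl)c3)nc2c1`: compound 2 gives < 100000 nM, again only a limit.
- Compound 3, `COc1ccc(CNc2nc3cc(N)cc(N)c3nc2-c2ccccc2)cc1OC`: compound 3 gives < 100000 nM, also only a limit.

Compound 3 therefore stands at a limit in this assay, with no exact number, and the two other measured compounds stand at limits as well. Among the compounds with values here, only one measured pair differs in a single place, and that step, a step that the two limits leave unreadable from compound 1 to compound 3, has a limit at each end, so its size and direction cannot be read. What is known is summarised by the limit of < 100000 nM in this assay, at which 2 of the 3 values shown sit, and (the limit of < 50200 nM in this assay, at which 1 of the 3 values shown sits).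

Compound 4, `COc1ccc(CNc2nc3cc(N)cc(N)c3nc2-c2ccccc2)cc1`, differs from compound 3 in one place: hydrogen in place of methoxy on an aromatic carbon. Within the data shown here, the same kind of change, hydrogen in place of methoxy on an aromatic carbon, is the one that separates compound 1 from compound 3, and that step gave no readable size. Among the measured compounds shown here, no measured step therefore points to a change in either direction, and the expectation is that compound 4 stays in the same region as compound 3, most likely again reported as a limit.

For compound 4 in this assay the estimated value is 40000 nM, with a range from 8000 nM to 100000 nM, which means an expected step that the limit leaves unreadable from compound 3 to compound 4.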

Compound 4, concentration lethal to 50% of the cells: 53700 nM
The estimate for compound 4 lay 1.3-fold (0.13 log units) below the measured number; the range from low to high includes it.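

Compound 3 gives < 100000 nM, which is a limit of the assay and not a number, so no size or direction can be read for the step to compound 4. The compounds shown leave open how far, and in which direction, putting hydrogen in place of methoxy on the aromatic ring shifts toxicity in this test.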